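This account rests on a few compounds, and the source may have more. Where it says the series, first, only, none or still open, it means among the compounds named here.

Working notes on the series. Compound 1 `O=C(O)c1cn(-c2ccc(F)cc2)c2cc(N3CCC(N4CCCCC4)CC3)c([N+](=O)[O-])cc2c1=O` carries the 4-(piperidin-1-yl)piperidin-1-yl group on the shared core. In an ADME assay on Vero cells (Chlorocebus sabaeus) for cytotoxicity, read by MTT assay, with a stated time of 72 h (a higher number here means that more compound is tolerated, a lower number that less compound is tolerated), compound 1 gives "not determined" (no result reported): no result was reported for it, so there is no value from which a step to another compound could be sized. Compound 3 `O=C(O)c1cn(-c2ccc(F)cc2)c2cc(N3CCC(n4c(=O)[nH]c5cc(Cl)ccc54)CC3)c([N+](=O)[O-])cc2c1=O` likewise gives "not determined" (no result reported) in this assay, with no reported result. The single measured point of the series is compound 2 `O=C(O)c1cn(C2CC2)c2cc(N3CCC(N4CCCCC4)CC3)c([N+](=O)[O-])cc2c1=O`, which in this assay gives 142000 nM; it shares the nitro-bearing core and the 4-(piperidin-1-yl)piperidin-1-yl group with compound 1 but differs elsewhere, so it serves only as a rough anchor for the level of tolerance seen in this set.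

Compound 4 `CC1CN(c2cc3c(cc2[N+](=O)[O-])c(=O)c(C(=O)O)cn3-c2ccc(F)cc2)CC(C)O1` is the next compound to be measured. It differs from compound 1 in one place: 2,6-dimethylmorpholin-4-yl in place of 4-(piperidin-1-yl)piperidin-1-yl on an aromatic carbon. With compound 1 unmeasured, no step in this assay can be stated for the change, neither its size nor its direction, and the expectation for compound 4 rests on the level shown by compound 2 alone. Compound 4 is expected to give about 120000 nM in this assay, with the estimate ranging from 40000 nM to 300000 nM.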

Compound 4, half-maximal cytotoxic concentration: 70800 nM
Compound 4: middle estimate off by 1.7-fold (0.23 log units), on the high side; the range from low to high includes it.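

In this assay no step can be read between compound 1 and compound 4, since compound 1 offers no single number to set against the new value. No evidence at hand bears on this result. The compounds shown leave open whether 2,6-dimethylmorpholin-4-yl in place of 4-(piperidin-1-yl)piperidin-1-yl changes tolerance, and in which direction.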